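A few compounds are considered here, and "the series" means these few. Any claim that something is new, unique, unknown or untested is made for them only; others in the source may bear on it.

Measured so far:
- compound 1, `Cc1ccccc1S(=O)(=O)N[C@H]1CCN(CCCOc2ccc(C(=O)C3CC3)cc2)C1`: 2200 nM
- compound 2, `CC(=O)c1ccc(OCCCN2CC[C@H](NC(=O)c3ccc(C#N)cc3)C2)cc1`: 6100 nM

Both compounds were run in an assay on isolated protein for binding affinity to histamine H2 receptor (Homo sapiens); a higher number here means a weaker inhibitor, a lower number a stronger inhibitor. Compound 1 holds the lowest of the two numbers; the nearest is compound 2, whose value is higher by a margin that lies beyond the usual scatter, so on these two numbers compound 1 is the stronger binder. For the measured compounds named here, no pair that differs in a single place has been measured, so the series gives no calibrated step to lean on.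

The next compound, compound 3, `N#Cc1ccc(S(=O)(=O)N[C@H]2CCN(CCCOc3ccc(C(=O)C4CC4)cc3)C2)cc1`, is reached from compound 1 by one change: 4-cyanophenyl in place of 2-methylphenyl on a sulfonyl sulfur. Going by the values given here, with no measured step of this kind available, the expectation is set without a reference. A modest shift in this assay toward a weaker binder seems more likely than a gain, but a step within the scatter in either direction is also quite possible; the estimated step from compound 1 to compound 3 is a 1.6-fold higher number from compound 1 to compound 3 (0.20 log units; within the scatter). In this assay compound 3 is expected to come in near 3500 nM, with a plausible range from 1200 nM to 10000 nM.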

Compound 3, inhibition constant: 1600 nM
Beside the measured number, compound 3's estimate is 2.2-fold (0.34 log units) above it; low and high end bracket the measured number.
By their numbers in this assay, from the lowest: compounds 3 and 1 (each within the scatter of the next); then compound 2.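

At the sulfonyl sulfur whose other neighbour is the sulfonamide nitrogen, the series now has its first single-place step in this assay: 4-cyanophenyl in place of 2-methylphenyl gives a 1.4-fold lower number from compound 1 to compound 3 (0.14 log units; within the scatter). This position therefore takes an exchange of one aryl group for another, here adding a nitrile with its hydrogen-bond acceptor and losing the methyl, without a shift that can be told from the scatter, so compound 1 and compound 3 stand level on this read-out. No measurement at hand accounts for this result.

The exchange alters two things at once, removing the methyl and adding the nitrile, so the two contributions may be offsetting or may both be small, and a plain phenyl group at this sulfur would help to tell these readings apart. For the compounds shown here, how far the tolerance extends also remains open, since a benzyl group or a carboxylic acid on the ring would test this position well beyond substituted phenyl groups, while compound 2 differs from both sulfonamides in more than one place and offers no step to this question.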